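This account rests on a few compounds, and the source may have more. Where it says the series, first, only, none or still open, it means among the compounds named here.

Compound 1 `CN(c1ccc2[nH]c(-c3n[nH]c4ccccc34)cc2n1)S(=O)(=O)c1ccc(Br)cc1` gives 7150 nM in a functional assay on KB cells (Homo sapiens) for antiproliferative activity, read by MTT assay, with a stated time of 72 h; on this read-out lower numbers stand for stronger inhibition and higher numbers for weaker inhibition. Compound 2 `COc1ccc(S(=O)(=O)N(C)c2ccc3[nH]c(-c4n[nH]c5ccccc45)cc3n2)cc1` gives 22100 nM in this assay. Compound 3 `COc1ccc(OC)c(S(=O)(=O)N(C)c2ccc3[nH]c(-c4n[nH]c5ccccc45)cc3n2)c1` gives 4380 nM in this assay.

Compound 3 carries the lowest of the three numbers; compound 1 is its nearest neighbour, and the gap between them lies within the scatter, whereas compound 2 lies furthest away, beyond the scatter. Compound 4 `CN(c1ccc2[nH]c(-c3n[nH]c4ccccc34)cc2n1)S(=O)(=O)c1cccc([N+](=O)[O-])c1` has not yet been measured. It differs from compound 3 in one place: 3-nitrophenyl in place of 2,5-dimethoxyphenyl on a sulfonyl sulfur. Going by the values given here, three measured steps bear on this, since all of them change the ring on the sulfonyl sulfur: a 3.1-fold higher number from compound 1 to compound 2 (0.49 log units; beyond the scatter), a 1.6-fold lower number from compound 1 to compound 3 (0.21 log units; within the scatter) and a 5.0-fold lower number from compound 2 to compound 3 (0.70 log units; beyond the scatter). These steps are modest at most, and none of them involves a nitro group, so the direction for compound 4 cannot be read off directly. Since compound 3 already holds the lowest number, a modest move upward, or none beyond the scatter, seems the most likely outcome. Compound 4 is therefore expected to give about 8000 nM, within a range of 2500 nM to 25000 nM. This estimate corresponds to a 1.8-fold higher number from compound 3 to compound 4 (0.26 log units; within the scatter).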

Compound 4, half-maximal inhibitory concentration: 5870 nM
Estimate against measurement, compound 4: 1.4-fold (0.13 log units) above; the range from low to high includes it.
By their numbers in this assay, from the lowest: compounds 3, 4 and 1 (each within the scatter of the next); then compound 2.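

In this assay, a 3-nitrophenyl ring on the sulfonyl sulfur sits level with two of the earlier rings, showing a 1.3-fold higher number from compound 3 to compound 4 (0.13 log units; within the scatter) and a 1.2-fold lower number from compound 1 to compound 4 (0.09 log units; within the scatter), and neither step goes beyond the scatter. Only 4-methoxyphenyl stands apart, as the step with a 3.8-fold lower number from compound 2 to compound 4 (0.58 log units; beyond the scatter) joins the earlier ones in placing compound 2 beyond the scatter from each of the other three compounds, so a nitro group fits this position as well as bromo or two methoxy groups do. No measurement explains why compound 2 alone stands apart.

The compounds shown leave open how a ring bearing an amine or a carboxylic acid would behave at this position. They also leave open what a plain phenyl ring, or a longer chain in place of the ring on the sulfonyl sulfur, would give.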